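The source may hold more compounds than are shown below. What is called first, only, known or untested is meant among the compounds shown, and "the series" means these compounds.

Measured so far in a functional assay on HL-60 cells (Homo sapiens) for inhibition, read by CCK-8 assay, with a stated time of 48 h, tested at 20 uM; a higher number here means more inhibition of growth at the concentration tested, a lower number less inhibition of growth:
- compound 1 `COc1ccc(Cc2nnc(NC(=O)/C(C#N)=C/c3ccccc3OS(=O)(=O)c3ccc(F)cc3)s2)cc1`: 25%
- compound 2 `Cc1ccc(S(=O)(=O)Oc2ccccc2/C=C(\C#N)C(=O)Nc2nnc(Cc3ccccc3)s2)cc1`: 16%
- compound 3 `N#C/C(=C\c1ccccc1OS(=O)(=O)c1ccc([N+](=O)[O-])cc1)C(=O)Nc1nnc(Cc2ccccc2)s1`: 20%

Compound 3 gives 20%, a value within the scatter of those of compound 1 and compound 2, so the three cannot be ranked. Compound 4 `N#C/C(=C\c1ccccc1OS(=O)(=O)c1ccc(F)cc1)C(=O)Nc1nnc(Cc2ccccc2)s1` has not yet been measured. It differs from compound 3 at one place: fluoro in place of nitro on an aromatic carbon. This is fluoro in place of nitro on an aromatic carbon, turning 4-nitrophenyl into 4-fluorophenyl. Going by the values given here, one measured step bears directly on this position: a number 4 percentage points higher from compound 2 to compound 3 (within the scatter), with nitro in place of methyl, and it stays small. Compound 1, which also carries the (4-fluorophenyl)sulfonyl group but differs elsewhere, gives 25%. No step beyond the scatter is therefore expected in this assay, and neither direction is favoured. The expected change is small: a number 1 percentage points higher from compound 3 to compound 4 (within the scatter). For compound 4 the estimated value is 21%, with an expected range of 10% to 33%.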

Compound 4, percent growth inhibition at one concentration: 22%
Compound 4: the middle estimate sits 1 percentage points below what was measured; the measured number falls inside the stated range.
By their numbers in this assay, from the lowest: compounds 2, 3, 4 and 1 (each within the scatter of the next).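

In this assay, going by these compounds alone, fluoro in place of nitro gives a number 2 percentage points higher from compound 3 to compound 4 (within the scatter) and fluoro in place of methyl gives a number 6 percentage points higher from compound 2 to compound 4 (within the scatter) so compound 4 completes a set of three groups at this place on the sulfonyl-bearing aromatic ring, with no step among them beyond the scatter. Compound 4 also pairs with compound 1 at a second place, where hydrogen in place of methoxy on an aromatic carbon gives a number 3 percentage points lower from compound 1 to compound 4 (within the scatter) and this change too stays within the scatter. No measurement bears on why these numbers stay so close.

The compounds shown leave open whether an amine or a carboxylic acid at the first place would give a step beyond the scatter. They also leave open whether a longer chain in place of methoxy at the second place would do so.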